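The source may report more compounds than this note shows. Statements on the series, on what has been measured and on what is new or still open speak of the compounds shown alone.

Of the compounds shown here, three sharing one core have been measured in a functional assay on A-375 cells (Homo sapiens) for antiproliferative activity, read by CCK-8 assay, with a stated time of 72 h, tested at 8 uM; on this read-out higher numbers stand for a stronger effect at the one concentration tested and lower numbers for a weaker effect. Compound 1 `Nc1ccccc1NC(=O)c1ccc(CSC(=S)N2CCN(Cc3ccccn3)CC2)cc1` gives 82.4% in this assay. Compound 3 `CC1CCN(C(=S)SCc2ccc(C(=O)Nc3ccccc3N)cc2)CC1` gives 87.4%, a number that lies within the usual scatter of the value for compound 1, so the two cannot be told apart on this read-out. Compound 2 `Nc1ccccc1NC(=O)c1ccc(CSC(=S)N2CCc3cc([N+](=O)[O-])ccc32)cc1` gives 29.5%, a number well below the other two and beyond the scatter. On these numbers compound 1 stands second of the three, close to compound 3 and far above compound 2.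

Compound 4 `Nc1ccccc1NC(=O)c1ccc(CSC(=S)N2CCN(c3cccnc3)CC2)cc1` has not yet been measured. It differs from compound 1 in one place: pyridin-3-yl in place of (pyridin-2-yl)methyl on an amine nitrogen in a ring. Among the measured compounds, the group on the amine nitrogen is the part that varies, and compound 1 and compound 3 both carry high numbers while compound 2 carries a low one; no measured pair shows this particular exchange, so its effect is not known from the data. The expectation is that compound 4 stays in the high range, with a step of a number 8.4 percentage points lower from compound 1 to compound 4 (within the scatter) that is small and, if anything, slightly downward, not clearly beyond the scatter. The estimate for compound 4 in this assay is 74%, within a range from 45% to 90%.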

Compound 4, a percentage reported as inhibition, at one concentration (the size of the read-out at that concentration, not a potency): 88.8%
The estimate for compound 4 lay 14.8 percentage points below the measured number, and the stated range covers the measured number.
By their numbers in this assay, from the lowest: compound 2; then compounds 1, 3 and 4 (each within the scatter of the next).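

In this assay, placing pyridin-3-yl where (pyridin-2-yl)methyl stood on the amine nitrogen in the ring gives a number 6.4 percentage points higher from compound 1 to compound 4 (within the scatter), so the two compounds cannot be told apart on this read-out. Within the data shown here, this is the first direct reading of a change at this position, and it shows that the large effect at the one concentration tested survives when the aromatic ring sits straight on the nitrogen, with no methyl link, and carries its ring nitrogen at a different place. Nothing at hand explains why the number holds, and the link and the place of the ring nitrogen change together here, so their separate contributions cannot be read from this one step.

The compounds shown leave open whether this tolerance extends to other groups on the same nitrogen, such as a plain phenyl, a pyridin-4-yl, an acetyl group or a longer chain like 2-(pyridin-2-yl)ethyl. Since the read-out gives the size of the effect at a single concentration, it also leaves open whether compound 1 and compound 4 differ in potency.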